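This account rests on a few compounds, and the source may have more. Where it says the series, first, only, none or still open, it means among the compounds named here.

In a physicochemical assay for solubility, in phosphate buffer, measured as kinetic solubility, at pH 7.4, tested at 250 uM (on this read-out lower numbers stand for lower solubility and higher numbers for higher solubility), compound 1 (`CCCCNc1ccc([N+](=O)[O-])cc1S(N)(=O)=O`) gives 85000 nM. Compound 2 (`CCCCCCCCNc1ccc([N+](=O)[O-])cc1S(N)(=O)=O`) gives < 1000 nM, which is a limit and not a number. That places compound 2 at the limit of < 1000 nM in this assay, at which 1 of the 3 values shown sits. Compound 3 (`CCCCCCNc1ccc([N+](=O)[O-])cc1S(=O)(=O)N(C)C`) reads 1000 nM. Compound 4 (`CCCCCCCCNc1ccc(C(=O)O)cc1S(N)(=O)=O`) differs from compound 2 in one place: carboxy in place of nitro on an aromatic carbon. Among the measured compounds shown here, no measured step covers this change. The nearest evidence is the large step of an at least 85-fold lower number from compound 1 to compound 2 (1.92 log units; beyond the scatter), which lies in the chain and so offers only a sense of scale. A large step to a higher number is expected, estimated as an at least 80-fold higher number from compound 2 to compound 4 (1.90 log units; beyond the scatter). Compound 4 is estimated at 80000 nM, with an expected range of 10000 nM to 250000 nM.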

Compound 4, solubility: > 250000 nM
Compound 4: no number, only a limit (the forecaster's own chance of this, stated with the estimate: 15%); middle value at least 3.1-fold (0.49 log units) from the limit.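

In this assay, among the compounds shown here, the aromatic carbon para to a group of 9 heavy atoms and meta to a sulfamoyl group also carries a large step, carboxy in place of nitro giving an at least 250-fold higher number from compound 2 to compound 4 (2.39 log units; beyond the scatter), whereas the only earlier step lay in the chain. The reading for compound 2 is a limit and not a number: the limit of < 1000 nM in this assay, at which 1 of the 4 values shown sits. The reading for compound 4 is also a limit and not a number: the limit of > 250000 nM in this assay, at which 1 of the 4 values shown sits.

The compounds shown leave open whether an amide or a nitrile at this position would give a step of similar size. They also leave open how far carboxy in place of nitro would move the shorter butyl chain of compound 1.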